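This account rests on a few compounds, and the source may have more. Where it says the series, first, only, none or still open, it means among the compounds named here.

Compound 1 `Cc1cc(O)c(C(=O)/C=C/c2ccc(F)cc2)c(-c2ccc(Br)cc2)c1C(=O)/C=C/c1ccc(F)cc1`: 20000 nM
Compound 2 `Cc1cc(O)c(C(=O)/C=C/c2ccc(Cl)cc2)c(-c2ccc(Cl)cc2)c1C(=O)/C=C/c1ccc(Cl)cc1`: 28000 nM

Both compounds were tested in a functional assay on MCF7 cells (Homo sapiens) for cytotoxicity, read by MTT assay, with a stated time of 24 h; a lower number here means a stronger inhibitor, a higher number a weaker inhibitor. Compound 1 gives 20000 nM in this assay, the lowest of the two numbers, but compound 2 with 28000 nM lies within the usual scatter of repeated measurements, so neither can be called the stronger of the pair. Both are weak inhibitors on this read-out.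

Compound 3 `Cc1cc(O)c(C(=O)/C=C/c2ccc(F)cc2)c(-c2ccccc2)c1C(=O)/C=C/c1ccc(F)cc1` has not yet been measured. It differs from compound 1 at a single place: hydrogen in place of bromo on an aromatic carbon. Cut one bond further out, the change reads 4-bromophenyl to phenyl. Within the data shown here, no pair of measured compounds shows this change, so there is no measured step to lean on. What compounds 1 and 2 do show is that exchanging halogens across the shared core moves the number little. Losing one heavy atom is expected to be a small step in this assay, if anything toward a somewhat higher number, and likely not beyond the scatter.

Compound 3 is therefore expected to give 26000 nM in this assay, within a range of 9000 nM to 75000 nM. That estimate means a step of a 1.3-fold higher number from compound 1 to compound 3 (0.11 log units; within the scatter).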

Compound 3, half-maximal inhibitory concentration: 20000 nM
Beside the measured number, compound 3's estimate is 1.3-fold (0.11 log units) above it; measured number inside the range.
By their numbers in this assay, from the lowest: compounds 1, 3 and 2 (each within the scatter of the next).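

Taking the bromo group off the 4-bromophenyl group, so that hydrogen stands on that aromatic carbon, gives no change at the digits printed from compound 1 to compound 3 (within the scatter) in this assay and is the only direct reading of this position among the compounds shown. Compound 1 and compound 2 differ in more than one place, so their pair could not isolate this group, whereas this single change does. With one heavy atom gone and the number unmoved, the bromo group is not needed to keep this level of activity, which remains weak, and the data shown offer no measured explanation of why the position accepts the change.

On these data alone, only bromo and hydrogen are compared here with the rest of the molecule held fixed, so it stays open whether a group of a different kind at this place, such as an amine, a carboxylic acid or a longer chain like butyl, would leave the number alone or shift it. Also open, as far as these compounds go, is whether removing the fluoro groups from the other two aromatic rings of compound 3 would prove just as uneventful.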